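A few compounds are considered here, and "the series" means these few. Any claim that something is new, unique, unknown or untested is made for them only; others in the source may bear on it.

Measured compounds:
compound 1 `CC(C)(C)Cc1c(-c2cccnc2)sc(N)c1C(=O)c1ccc(Cl)cc1`: 1%
compound 2 `CC(C)(C)Cc1c(-c2ccccn2)sc(N)c1C(=O)c1ccc(Cl)cc1`: 1%
compound 3 `COc1cccc(-c2sc(N)c(C(=O)c3ccc(Cl)cc3)c2CC(C)(C)C)c1`: 1%

These values come from an assay on CHO cells for displacement of a labelled ligand from adenosine receptor A1 (Homo sapiens), read by scintillation counting, tested at 10 uM; on this read-out higher numbers stand for more inhibition at the one concentration tested (going by the name of the read-out) and lower numbers for less inhibition. Compound 3 stands level with compounds 1 and 2 at the digits shown: the steps of no change at the digits printed from compound 1 to compound 3 (within the scatter) and no change at the digits printed from compound 2 to compound 3 (within the scatter) lie within the scatter, as does no change at the digits printed from compound 1 to compound 2 (within the scatter). Compound 4 `CC(C)(C)Cc1c(Br)sc(N)c1C(=O)c1ccc(Cl)cc1` has not yet been measured. It differs from compound 3 in one place: bromo in place of 3-methoxyphenyl on an aromatic carbon.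

Which of the measured steps bear on this change? For the measured compounds named here, each of the three exchanges one ring group for another at the same aromatic carbon; none exchanges such a group for a single atom, so no measured step covers the change to bromo directly. What the measured steps do show is that three different ring groups at this carbon all left the read-out at the same low level. Since all three compounds sit near the bottom of the scale, compound 4 is expected to stay there too, with the step of a number 1 percentage points higher from compound 3 to compound 4 (within the scatter) expected to be no change beyond the scatter. Compound 4 is therefore estimated at 2%, with a range from -6% to 14%.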

Compound 4, a percentage reported as inhibition, at one concentration (the size of the read-out at that concentration, not a potency): 1%
Estimate against measurement, compound 4: 1 percentage points above, within the range that was stated.
By their numbers in this assay, from the lowest: compounds 1, 2, 3 and 4 (each within the scatter of the next).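

Putting a lone bromo in place of a whole ring group at this carbon gives, in this assay, no change at the digits printed from compound 3 to compound 4 (within the scatter) and no change at the digits printed from compound 2 to compound 4 (within the scatter) and also no change at the digits printed from compound 1 to compound 4 (within the scatter) in these three direct comparisons. The earlier compounds shown here only exchanged one ring group for another, whereas this position, next to the ring sulfur, has now carried either a ring group or a single atom with the read-out staying at the bottom of its scale. Nothing available offers a reason for this flat result.

As far as these compounds go, with all four compounds sitting this low, it remains open whether any group at this carbon can raise the inhibition, such as an amine, a carboxylic acid or a longer chain. From the compounds shown here alone, it also remains open whether changing the neopentyl group or the (4-chlorophenyl)carbonyl group would lift the read-out from the bottom of the scale.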